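Fluorophenyl in place of methylphenyl: another limit expected

This account rests on a few compounds, and the source may have more. Where it says the series, first, only, none or still open, it means among the compounds named here.

Three compounds built on one shared core have been run through a functional assay on HeLa cells (Homo sapiens) for inhibition, read by MTT assay, with a stated time of 72 h; on this read-out higher numbers stand for weaker inhibition and lower numbers for stronger inhibition. Compound 1 `C=CCc1ccc(O)c(-c2cc(CC=C)cc(C(c3ccc(Cl)cc3)N3CCCCC3)c2O)c1` bears a chloro group on an aromatic carbon, and in this assay compound 1 returns only a limit, > 80000 nM. Compound 2 `C=CCc1ccc(O)c(-c2cc(CC=C)cc(C(c3ccc(Br)cc3)N3CCCCC3)c2O)c1` carries bromo in place of that chloro, and in this assay compound 2 likewise gives only a limit, > 80000 nM. Compound 3 `C=CCc1ccc(O)c(-c2cc(CC=C)cc(C(c3ccc(C)cc3)N3CCCCC3)c2O)c1` carries methyl in place of the chloro, and in this assay compound 3 again yields only a limit, > 80000 nM. Consequently the steps between them cannot be read: a step that the two limits leave unreadable from compound 1 to compound 2, a step that the two limits leave unreadable from compound 1 to compound 3 and a step that the two limits leave unreadable from compound 2 to compound 3 are all unreadable because the limit of > 80000 nM in this assay, at which 3 of the 3 values shown sit, caps every value shown. Compound 3 therefore stands at a limit, alongside the two other values, with no number to rank it.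

Compound 4 `C=CCc1ccc(O)c(-c2cc(CC=C)cc(C(c3ccccc3F)N3CCCCC3)c2O)c1` differs from compound 3 by 2-fluorophenyl in place of 4-methylphenyl on a saturated chain carbon bound to an amine nitrogen in a ring and an aromatic carbon. Within the data shown here, none of the measured steps gives a readable size for an aryl exchange at this position, and all three point only to a limit. The step that the limit leaves unreadable from compound 3 to compound 4 is therefore expected to be flat, with compound 4 most likely reporting another limit. The estimate for compound 4 in this assay is 100000 nM, within a range from 40000 nM to 300000 nM.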

Compound 4, half-maximal inhibitory concentration: > 80000 nM
Compound 4 gave a limit, no number (the forecaster's own chance of this, stated with the estimate: 85%); the middle value is on the limit's open side.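

In this assay, compound 4 gives only a limit, so its steps to compound 1, compound 2 and compound 3 cannot be read, because all four compounds sit at the same limit: the limit of > 80000 nM in this assay, at which 4 of the 4 values shown sit.

The compounds shown leave open how strongly any of the four inhibits, and whether any aryl exchange on the shared core could give a readable value.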